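The compounds below may be only part of what the source reports. "The series", "measured", "known", "first", "only" and "open" are said of these compounds alone.

Compound 2 `COc1cccc(CCSc2nc3c(c(=O)n(C)c(=O)n3C)n2C)c1` gives 125 nM in an assay on microsomes for inhibition of Amine oxidase [flavin-containing] B (Homo sapiens), read by fluorescence and spectrophotometry, with a stated time of 20 min (on this read-out higher numbers stand for weaker inhibition and lower numbers for stronger inhibition), the higher of the two numbers measured; compound 1 `Cn1c(=O)c2c(nc(SCCc3cccc(Br)c3)n2C)n(C)c1=O` gives 40 nM in this assay. Among the measured compounds shown here, the one measured step bearing on the series, a 3.1-fold higher number from compound 1 to compound 2 (0.49 log units; beyond the scatter), was modest and came from methoxy in place of bromo. Compound 3 `Cn1c(=O)c2c(nc(SCCCc3ccc(Cl)cc3)n2C)n(C)c1=O` differs from compound 2 by 4-chlorobenzyl in place of 3-methoxyphenyl on a saturated chain carbon, two bonds along the chain from a sulfur, returning a halogen to the aromatic ring on a longer chain. A modest downward step is expected, a 2.1-fold lower number from compound 2 to compound 3 (0.32 log units; beyond the scatter), because compound 1 gives 40 nM. For compound 3 the estimate in this assay is 60 nM, within 20 nM to 200 nM.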

Compound 3, half-maximal inhibitory concentration: 61 nM
Compound 3: the middle estimate sits 1.0-fold (0.01 log units) below what was measured, and the stated range covers the measured number.
By their numbers in this assay, from the lowest: compounds 1 and 3 (each within the scatter of the next); then compound 2.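

In this assay the swap to 4-chlorobenzyl from 3-methoxyphenyl gives a 2.0-fold lower number from compound 2 to compound 3 (0.31 log units; beyond the scatter) at this chain carbon. Set against 3-bromophenyl, 4-chlorobenzyl gives a 1.5-fold higher number from compound 1 to compound 3 (0.18 log units; within the scatter) and so cannot be told apart from the bromo group here. Nothing available explains either step.

Both the halogen and the chain length change together in 4-chlorobenzyl, so the compounds shown leave open which of them carries the step. They also leave open how an amine or a carboxylic acid on the ring, or a still longer chain, would read.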